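The source may hold more compounds than are shown below. What is called first, only, known or untested is meant among the compounds shown, and "the series" means these compounds.

Measured so far:
compound 1 `O=C(Nc1cccc([N+](=O)[O-])c1)Nc1nc2ccc(Cl)cc2s1` — 2.21 ug/mL
compound 2 `COc1ccc2sc(NC(=O)c3ccc(C)cc3)nc2c1` — > 10 ug/mL
compound 3 `Cc1ccc(C(=O)Nc2nc3cc(C)cc(C)c3s2)cc1` — 2.17 ug/mL

In a functional assay on SK-HEP1 cells (Homo sapiens) for antiproliferative activity, read by sulforhodamine B assay (on this read-out higher numbers stand for weaker inhibition of growth and lower numbers for stronger inhibition of growth), compound 1 gives 2.21 ug/mL and compound 3 gives 2.17 ug/mL. Compound 2 stands apart from these two: its result is the limit of > 10 ug/mL in this assay, at which 1 of the 3 values shown sits, a limit of the assay and not a number, so no growth inhibition was reached within the tested range and no value can be placed for it.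

Compound 4 `COc1ccc2sc(NC(=O)c3ccc(C#N)cc3)nc2c1` is the next member, and it differs from compound 2 by cyano in place of methyl on an aromatic carbon. Going by the values given here, no measured pair contains this exchange, and the limit on compound 2 gives no starting number from which a shift could be read. With nothing to point either way, the working expectation in this assay is a step no larger than the usual scatter, in either direction, and a fair chance that compound 4 also returns only a limit.

Compound 4 is estimated at 10 ug/mL, with a range from 3 ug/mL to 30 ug/mL, and the step from compound 2 to compound 4 is expected to be a number no higher from compound 2 to compound 4 (the limit leaves the size open).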

Compound 4, concentration for 50% growth inhibition: > 10 ug/mL
Compound 4: no number, only a limit; the forecaster's own chance of this, stated with the estimate: 55%; the middle value lies on the limit itself.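

Compound 2 and compound 4 both return only a limit, so cyano in place of methyl yields no readable step between them: the limit of > 10 ug/mL in this assay, at which 2 of the 4 values shown sit.

The compounds shown leave open whether this exchange on an aromatic carbon shifts growth inhibition at all, and in which direction.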